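Arylamino to pyrrolidinyl swap on the shared core

This account rests on a few compounds, and the source may have more. Where it says the series, first, only, none or still open, it means among the compounds named here.

Values in a functional assay on HeLa cells (Homo sapiens) for inhibition, read by sulforhodamine B assay; on this read-out lower numbers stand for stronger inhibition and higher numbers for weaker inhibition:
compound 1 `O=C1C(Nc2cccc(Cl)c2)=CC(=O)c2c1nc1n2[C@H]2OC[C@@H](O)[C@H]2OC1`: 7970 nM
compound 2 `COc1ccccc1NC1=CC(=O)c2c(nc3n2[C@H]2OC[C@@H](O)[C@H]2OC3)C1=O`: 7460 nM
compound 3 `CCOc1ccccc1NC1=CC(=O)c2c(nc3n2[C@H]2OC[C@@H](O)[C@H]2OC3)C1=O`: 8300 nM

Compound 2 stands alongside the other two rather than apart from them: a 1.1-fold lower number from compound 1 to compound 2 (0.03 log units; within the scatter), a 1.1-fold higher number from compound 2 to compound 3 (0.05 log units; within the scatter), and likewise a 1.0-fold higher number from compound 1 to compound 3 (0.02 log units; within the scatter). Among the compounds with values here, all three numbers lie within the scatter of one another, so no compound in the set is distinguished by the data.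

Compound 4 `O=C1C(N2CCCC2)=CC(=O)c2c1nc1n2[C@H]2OC[C@@H](O)[C@H]2OC1` is not yet measured. Against compound 2 the change is pyrrolidin-1-yl in place of (2-methoxyphenyl)amino on a double-bonded ring carbon. Within the data shown here, none of the measured steps touches a change of this kind: the steps among compounds 1, 2 and 3 only exchange one aryl substituent for another, or put methyl in place of hydrogen on a saturated chain carbon bound to an oxygen on an aromatic ring, and all of them stay within the scatter. Among the measured compounds shown here, the move to compound 4 removes the aromatic ring and the hydrogen-bond donor entirely, and the series offers no precedent for it. The expectation for compound 4 is therefore a number near that of compound 2 or somewhat higher, held with wide uncertainty, and a 1.3-fold higher number from compound 2 to compound 4 (0.13 log units; within the scatter) is the expected step. Compound 4 is estimated at 10000 nM, expected to fall between 3000 nM and 35000 nM.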

Compound 4, half-maximal inhibitory concentration: > 16000 nM
Compound 4: no number, only a limit (the forecaster's own chance of this, stated with the estimate: 15%); middle value at least 1.6-fold (0.20 log units) from the limit.
By their numbers in this assay, from the lowest: compounds 2, 1 and 3 (each within the scatter of the next). At a limit, above all of these: compound 4.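

In this assay compound 4 reads as a limit of the assay and not as a number: the limit of > 16000 nM in this assay, at which 1 of the 4 values shown sits.

Pyrrolidin-1-yl in place of (2-methoxyphenyl)amino on the double-bonded ring carbon gives an at least 2.1-fold higher number from compound 2 to compound 4 (0.33 log units; beyond the scatter), the only step in the series printed as beyond the scatter, while pyrrolidin-1-yl in place of (3-chlorophenyl)amino gives an at least 2.0-fold higher number from compound 1 to compound 4 (0.30 log units; that floor lies within the scatter), so the second comparison does not by itself confirm the first. Within the data shown here, compounds 1, 2 and 3 showed only that exchanging one arylamino group for another left the numbers within the scatter; compound 2 and compound 4 now show that this position is not indifferent to every replacement.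

As far as these compounds go, this change removes the aromatic ring and the hydrogen-bond donor together, so the data do not say which of the two goes with the step, and the size of the step stays unknown. A cyclopentylamino group, which keeps the amine hydrogen without the aromatic ring, and a (2-methoxyphenyl)(methyl)amino group, which keeps the aromatic ring without the amine hydrogen, would separate the two.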